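The source may report more compounds than this note shows. Statements on the series, on what has been measured and on what is new or still open speak of the compounds shown alone.

Measured compounds:
compound 1 `Cn1c(SCC(=O)Nn2c(COc3ccc(Cl)cc3Cl)nc3ccccc3c2=O)nc(-c2ccccc2)c(C#N)c1=O`: 51.9%
compound 2 `N#Cc1c(Nc2ccccc2)nc(SCC(=O)Nn2c(COc3ccc(Cl)cc3Cl)nc3ccccc3c2=O)nc1-c1ccccc1`: 71.2%

In a functional assay on the whole organism (strain albino) for inhibition, with Rattus norvegicus as the target, read by paw edema, with stated times of 1 h and 0.5 h, at a dose of 100 mg/kg by the oral route (on this read-out higher numbers stand for more inhibition at the one dose given (going by the name of the read-out) and lower numbers for less inhibition), compound 2 gives the higher of the two numbers; compound 1 sits lower, a gap beyond the usual scatter. Compound 3 `N#Cc1c(Nc2ccc(O)cc2)nc(SCC(=O)Nn2c(COc3ccc(Cl)cc3Cl)nc3ccccc3c2=O)nc1-c1ccccc1` differs from compound 2 by hydroxy in place of hydrogen on an aromatic carbon, on an aromatic carbon of a six-membered aromatic ring of carbon only. Going by the values given here, no measured pair differs by this change, so nothing yet shows its size. The expected step in this assay, a number 3.2 percentage points lower from compound 2 to compound 3 (within the scatter), is small and in neither direction beyond the scatter. Compound 3 is therefore estimated at 68%, within 52% to 82%.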

Compound 3, a percentage reported as inhibition, in the whole organism at one dose (the size of the read-out at that dose, not a potency): 61.5%
Compound 3: middle estimate off by 6.5 percentage points, on the high side; low and high end bracket the measured number.
By their numbers in this assay, from the lowest: compounds 1, 3 and 2 (each within the scatter of the next, the first and the last beyond it).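

Phenyl to 4-hydroxyphenyl gives the first read on this position in this assay, with a number 9.7 percentage points lower from compound 2 to compound 3 (within the scatter) as its step. Hydroxy on this aromatic carbon, para to a large group, therefore leaves compound 3 not separated from compound 2 at the one dose given. Nothing measured on hand accounts for the size of this step. From the compounds shown here alone, whether methoxy, an amine or a carboxylic acid in the same place would give a step beyond the scatter stays open. So does whether a longer chain there would be separated from compound 2.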